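Swapping the benzyl ring substituent on a shared core

This account rests on a few compounds, and the source may have more. Where it says the series, first, only, none or still open, it means among the compounds named here.

Measured compounds:
- compound 1, `Cc1ccc(NC(=O)NC(=O)c2ccc(OCc3ccccc3F)cc2)cc1-c1nc2ccccc2[nH]1`: 2520 nM
- compound 2, `Cc1ccc(COc2ccc(C(=O)NC(=O)Nc3ccc(C)c(-c4nc5ccccc5[nH]4)c3)cc2)cc1`: 4250 nM
- compound 3, `Cc1ccc(NC(=O)NC(=O)c2ccc(OCc3ccc(Cl)c(Cl)c3)cc2)cc1-c1nc2ccccc2[nH]1`: 6080 nM

All three share one core and differ only in the ring sitting on a saturated chain carbon bound to an oxygen on an aromatic ring. In a functional assay on MGC-803 cells (Homo sapiens) for inhibition, read by MTT assay, with a stated time of 48 h (a lower number here means a stronger inhibitor, a higher number a weaker inhibitor), compound 3 has the highest of the three numbers: the step of a 2.4-fold higher number from compound 1 to compound 3 (0.38 log units; beyond the scatter) is beyond the scatter, whereas a 1.4-fold higher number from compound 2 to compound 3 (0.16 log units; within the scatter) is within it, so compound 3 and compound 2 cannot be told apart, and a 1.7-fold higher number from compound 1 to compound 2 (0.23 log units; within the scatter) is likewise within the scatter.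

Compound 4, `Cc1ccc(NC(=O)NC(=O)c2ccc(OCc3ccc(F)cc3)cc2)cc1-c1nc2ccccc2[nH]1`, carries the change (4-fluorophenyl in place of 3,4-dichlorophenyl on a saturated chain carbon bound to an oxygen on an aromatic ring). Going by the values given here, two measured steps bear on it: the fluorine-bearing ring of compound 1 gave the lowest number, and the para-substituted ring of compound 2 sat close to compound 3. A modest fall in the number is therefore expected, a 1.7-fold lower number from compound 3 to compound 4 (0.24 log units; within the scatter), landing near compound 1 and compound 2 rather than beyond them. For compound 4 the estimate in this assay is 3500 nM, with a range from 1500 nM to 8000 nM.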

Compound 4, half-maximal inhibitory concentration: 160 nM
Compound 4: the middle estimate sits 22-fold (1.34 log units) above what was measured; measured number below the stated range.
By their numbers in this assay, from the lowest: compound 4; then compounds 1, 2 and 3 (each within the scatter of the next, the first and the last beyond it).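

Among the first three compounds, changing the ring at this position shifted the number only slightly, but the 4-fluorophenyl ring shows that the position can matter far more in this assay (a 38-fold lower number from compound 3 to compound 4 (1.58 log units; beyond the scatter); a 27-fold lower number from compound 2 to compound 4 (1.42 log units; beyond the scatter)). Carrying a fluorine is not enough by itself, since the 2-fluorophenyl and 4-fluorophenyl rings, whose names differ only in the fluorine's location, are far apart (a 16-fold lower number from compound 1 to compound 4 (1.20 log units; beyond the scatter)). No measurement shown explains why compound 4 stands apart from the other three.

As far as these compounds go, it remains open whether this large drop belongs to fluorine alone or would also appear with a 4-chlorophenyl or 4-methoxyphenyl ring. A 3-fluorophenyl ring would complete the comparison of fluorine locations, and a 4-aminophenyl ring would test a very different group here.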